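A few compounds are considered here, and "the series" means these few. Any claim that something is new, unique, unknown or untested is made for them only; others in the source may bear on it.

In a functional assay on MKN-45 cells (Homo sapiens) for cytotoxicity, read by MTT assay, with a stated time of 72 h (a higher number here means a weaker inhibitor, a lower number a stronger inhibitor), the measured compounds are:

compound 1 `COc1cc2c(Oc3ccc(NC(=O)c4nn(-c5ccccc5F)c(=O)c5ccccc45)cc3F)ccnc2cc1OCCCN1CCCC1`: 140 nM
compound 2 `COc1cc2c(Oc3ccc(NC(=O)c4nn(-c5ccc([N+](=O)[O-])cc5)c(=O)c5ccccc45)cc3F)ccnc2cc1OCCCN1CCCC1`: 1620 nM
compound 3 `COc1ccc(-n2nc(C(=O)Nc3ccc(Oc4ccnc5cc(OCCCN6CCCC6)c(OC)cc45)c(F)c3)c3ccccc3c2=O)cc1`: 1320 nM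

Compound 2 gives the highest number of the three. Compound 3 lies within the scatter of it (a 1.2-fold lower number from compound 2 to compound 3 (0.09 log units; within the scatter)), whereas compound 1 stands far lower, as the step of a 12-fold higher number from compound 1 to compound 2 (1.06 log units; beyond the scatter) shows; the step of a 9.4-fold higher number from compound 1 to compound 3 (0.97 log units; beyond the scatter) points the same way. Compound 4 `COc1cc2c(Oc3ccc(NC(=O)c4nn(-c5ccc([N+](=O)[O-])cc5)c(=O)c5ccccc45)cc3F)ccnc2cc1OCCCN1CCN(C)CC1` differs from compound 2 by 4-methylpiperazin-1-yl in place of pyrrolidin-1-yl on a saturated chain carbon, three bonds along the chain from an oxygen on an aromatic ring. For the measured compounds named here, none of the measured steps touches this part of the molecule; all three vary only the group on the aromatic nitrogen. With no direct guide, the expectation is a step within the scatter, a 1.0-fold lower number from compound 2 to compound 4 (0.01 log units; within the scatter). Compound 4 is therefore estimated at 1600 nM, with a range of 700 nM to 3700 nM.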

Compound 4, half-maximal inhibitory concentration: 1320 nM
Estimate against measurement, compound 4: 1.2-fold (0.08 log units) above; low and high end bracket the measured number.
By their numbers in this assay, from the lowest: compound 1; then compounds 3, 4 and 2 (each within the scatter of the next).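

In this assay, the only change shown at the end of the chain, 4-methylpiperazin-1-yl in place of pyrrolidin-1-yl, gives a 1.2-fold lower number from compound 2 to compound 4 (0.09 log units; within the scatter). With 4-nitrophenyl on the aromatic nitrogen, this position therefore accepts the six-membered ring with its second nitrogen without a step beyond the scatter. Nothing at hand accounts for this result.

Still open, from the compounds shown here alone, is whether the same change reads alike with the 2-fluorophenyl group of compound 1 on the aromatic nitrogen, and whether a morpholine ring or a primary amine at the chain end stays within the scatter.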